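This account rests on a few compounds, and the source may have more. Where it says the series, first, only, none or still open, it means among the compounds named here.

In a physicochemical assay for lipophilicity, at pH 7.4 (on this read-out lower numbers stand for lower lipophilicity and higher numbers for higher lipophilicity), compound 1 `Cc1cc(S(=O)(=O)NCCCC[C@@H](Nc2cc(C)c(F)c(C)c2)C(=O)NO)ccc1F` gives < 3, which is a limit and not a number. Compound 2 `Cc1cc(N[C@H](CCCCNCc2ccccc2F)C(=O)NO)cc(C)c1F` gives < 3, likewise a limit. Compound 2 thus stands at the limit of < 3 in this assay, at which 2 of the 2 values shown sit. Compound 3 `COc1ccc(CNCCCC[C@@H](Nc2cc(C)c(F)c(C)c2)C(=O)NO)cc1` carries 4-methoxyphenyl in place of 2-fluorophenyl on a saturated chain carbon bound to an amine nitrogen, with 4-methoxyphenyl in place of 2-fluorophenyl on a saturated chain carbon bound to an amine nitrogen. Among the measured compounds shown here, no measured step covers this change. The expected step, a step that the limit leaves unreadable from compound 2 to compound 3, is none beyond the scatter in this assay. For compound 3 the estimated value is 2.2, with an expected range from 1.4 to 2.9.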

Compound 3, distribution coefficient: < 3
Compound 3: a limit, no number; the forecaster's own chance of this, stated with the estimate: 80%; the middle value does not contradict the limit.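

In this assay, among the compounds shown here, compound 2 and compound 3 each give only a limit, so no step between them can be read. The compounds shown leave open whether 4-methoxyphenyl in place of 2-fluorophenyl shifts the value in this assay at all.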